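A few compounds are considered here, and "the series" means these few. Any claim that something is new, unique, unknown or untested is made for them only; others in the source may bear on it.

Measured compounds:
- Compound 1, `C[C@@H]1CN(c2scnc2-c2nc3ccccc3[nH]2)CCN1C(=O)Cn1cnc2cccnc21`: 830 nM
- Compound 2, `COc1ncc(-c2nc(C(F)(F)F)sc2N2CCN(C(=O)Cn3cnc4cccnc43)[C@H](C)C2)cn1`: 177 nM
- Compound 3, `COc1ncc(-c2nc(C(F)(F)F)sc2N2CCN(C(=O)Cn3nc(C)nc3C)[C@H](C)C2)cn1`: 558 nM

In a functional assay on U2OS cells for antagonist activity at C-X-C chemokine receptor type 3 (Homo sapiens), read by beta-arrestin recruitment (a lower number here means a stronger inhibitor, a higher number a weaker inhibitor), compound 3 stands second highest of the three numbers. Its nearest neighbour is compound 1, whose value is within the scatter of it, so no order between the two can be claimed. Going by the values given here, its furthest neighbour is compound 2: the single one-place step, a 3.2-fold higher number from compound 2 to compound 3 (0.50 log units; beyond the scatter), lies beyond the scatter and is modest in size.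

Compound 4, `Cc1nc(C)n(CC(=O)N2CCN(c3sc(C(F)(F)F)nc3-c3ccc(C(F)(F)F)nc3)C[C@H]2C)n1`, differs from compound 3 only in the group on the five-membered aromatic ring: 6-(trifluoromethyl)pyridin-3-yl in place of 2-methoxypyrimidin-5-yl on an aromatic carbon. Among the compounds with values here, no measured pair shows this exchange, and the one step that is known, from compound 2 to compound 3, concerns a different part of the molecule. There is therefore no direct basis in the data for a direction, and the expected step in this assay is one that may well stay within the scatter.

Compound 4 is estimated at 500 nM in this assay, with a range of 180 nM to 1400 nM, which means an expected step of a 1.1-fold lower number from compound 3 to compound 4 (0.05 log units; within the scatter).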

Compound 4, half-maximal inhibitory concentration: 608 nM
Estimate against measurement, compound 4: 1.2-fold (0.08 log units) below; the range from low to high includes it.
By their numbers in this assay, from the lowest: compound 2; then compounds 3, 4 and 1 (each within the scatter of the next).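

In this assay the exchange of 2-methoxypyrimidin-5-yl for 6-(trifluoromethyl)pyridin-3-yl, on the aromatic carbon next to the ring nitrogen, gives a 1.1-fold higher number from compound 3 to compound 4 (0.04 log units; within the scatter) and so allows no order between the two compounds, even though the entering group has more heavy atoms, one ring nitrogen in place of two, and fewer hydrogen-bond acceptors. Going by these compounds alone, the only earlier one-place step, a 3.2-fold higher number from compound 2 to compound 3 (0.50 log units; beyond the scatter) in this assay for the group on the saturated chain carbon bound to the carbonyl carbon, lay in a different part of the molecule and beyond the scatter, so this is the first reading at the aromatic position, and there these two quite different six-membered aromatic rings cannot be told apart. Nothing available bears on why the two groups read alike.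

As far as these compounds go, the exchange is read only with the five-membered aromatic ring with 3 hetero atoms on the chain, so whether it would also read alike with the larger group of compound 2 stays open. From the compounds shown here alone, how an amine or a carboxylic acid on either ring at this position would read also remains unknown.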